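This account rests on a few compounds, and the source may have more. Where it says the series, first, only, none or still open, it means among the compounds named here.

Compound 2 `O=C1c2ccccc2S(=O)(=O)N1CCCCCCN1CCN(c2ccccc2F)CC1` gives 322 nM in an ADME assay on HEK293 cells for displacement of a labelled ligand from 5-hydroxytryptamine receptor 7 (Homo sapiens), read by radioligand binding, with a stated time of 1 h (on this read-out higher numbers stand for weaker inhibition and lower numbers for stronger inhibition), the highest of the three numbers in hand. Compound 1 `O=C1c2ccccc2S(=O)(=O)N1CCCCCCN1CCN(c2ccccc2Cl)CC1` gives 120 nM in this assay, and compound 3 `O=C1c2ccccc2S(=O)(=O)N1CCCCCCN1CCN(c2cccc3ccccc23)CC1` gives 20 nM. The measured steps are a 2.7-fold higher number from compound 1 to compound 2 (0.43 log units; beyond the scatter), a 6.0-fold lower number from compound 1 to compound 3 (0.78 log units; beyond the scatter), and a 16-fold lower number from compound 2 to compound 3 (1.21 log units; beyond the scatter).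

Compound 4 `O=C1c2ccccc2S(=O)(=O)N1CCCCCCN1CCN(c2cccc3cccnc23)CC1` has not yet been measured. It differs from compound 2 in one place: quinolin-8-yl in place of 2-fluorophenyl on an amine nitrogen in a ring. Among the compounds with values here, the step that bears most directly on this change is the one from compound 2 to compound 3, where a second ring replaced a single ring on the same amine nitrogen and the number fell by a large margin; the step from compound 1 to compound 3 points the same way. Quinolin-8-yl is named here for the first time, so no step measures its nitrogen, but its two rings match naphthalen-1-yl in layout. A large fall in this assay is therefore expected, an 11-fold lower number from compound 2 to compound 4 (1.03 log units; beyond the scatter). Compound 4 is estimated at 30 nM in this assay, within a range of 8 nM to 120 nM.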

Compound 4, inhibition constant: 21 nM
For compound 4 the middle estimate is 1.4-fold (0.15 log units) above the measured one; measured number inside the range.
By their numbers in this assay, from the lowest: compounds 3 and 4 (each within the scatter of the next); then compound 1; then compound 2.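

In this assay, the second ring again brings a large change when it carries a ring nitrogen: quinolin-8-yl on the amine nitrogen in a ring gives the large step ((a 15-fold lower number from compound 2 to compound 4 (1.19 log units; beyond the scatter))) and a modest one against the 2-chlorophenyl group (a 5.7-fold lower number from compound 1 to compound 4 (0.76 log units; beyond the scatter)). Set against naphthalen-1-yl, the six-membered aromatic ring with one hetero atom, which adds one hydrogen-bond acceptor by count, makes no difference beyond the scatter (a 1.1-fold higher number from compound 3 to compound 4 (0.02 log units; within the scatter)), so this position accepts either of the two groups equally on this read-out. Nothing given here explains why these two-ring groups differ from the single-ring ones.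

Going by these compounds, it remains open whether a 2-methoxyphenyl or an indol-4-yl group on the same amine nitrogen would match the two-ring groups. Also open, on these data alone, is how a shorter chain to the shared core would change the number.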